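The source may report more compounds than this note shows. Statements on the series, on what has been measured and on what is new or still open speak of the compounds shown alone.

Among the compounds with values here, compound 2 `Cc1ccccc1/C=C/C(=O)NNC(=O)c1ccc2c(c1)OCCO2` gives 7710 nM in a functional assay on cells (Cancer cell lines, Homo sapiens) for inhibition, read by MTT assay, with a stated time of 48 h (on this read-out lower numbers stand for stronger inhibition and higher numbers for weaker inhibition), the highest of the two numbers so far; compound 1 `O=C(/C=C/c1cccc(Cl)c1)NNC(=O)c1ccc2c(c1)OCCO2` gives 3560 nM in this assay. Within the data shown here, the only measured step, a 2.2-fold higher number from compound 1 to compound 2 (0.34 log units; beyond the scatter), swapped the aryl group at the same place. Compound 3 `O=C(/C=C/c1cccc(F)c1)NNC(=O)c1ccc2c(c1)OCCO2` is not yet measured; its change is 3-fluorophenyl in place of 2-methylphenyl on a double-bonded chain carbon bound to a double-bonded chain carbon, which returns a halogen to the position held in compound 1, so a step back toward compound 1 is expected, roughly a 1.7-fold lower number from compound 2 to compound 3 (0.23 log units; within the scatter) in this assay. Compound 3 is therefore estimated at 4500 nM, within 2000 nM to 10000 nM.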

Compound 3, half-maximal inhibitory concentration: 4110 nM
Beside the measured number, compound 3's estimate is 1.1-fold (0.04 log units) above it; measured number inside the range.
By their numbers in this assay, from the lowest: compounds 1, 3 and 2 (each within the scatter of the next, the first and the last beyond it).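

In this assay, fluoro in place of chloro on an aromatic carbon gives (a 1.2-fold higher number from compound 1 to compound 3 (0.06 log units; within the scatter)), so these two halogens cannot be told apart on this ring. 3-fluorophenyl in place of 2-methylphenyl gives (a 1.9-fold lower number from compound 2 to compound 3 (0.27 log units; within the scatter)), so compound 3 cannot be separated from either compound 1 or compound 2, although those two differ beyond the scatter. Nothing measured here gives a reason for these numbers. The 2-methylphenyl group differs from the halogen-bearing rings in both the group and its ring position. 3-methylphenyl would be needed to separate those two changes. Going by these compounds, how an amine or a carboxylic acid on this ring would read also stays open.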